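The source may hold more compounds than are shown below. What is called first, only, known or untested is meant among the compounds shown, and "the series" means these compounds.

Measured compounds and their values in an assay on CHO cells for antagonist activity at transient receptor potential cation channel subfamily V member 1 (Homo sapiens), read by FLIPR; a lower number here means a stronger inhibitor, a higher number a weaker inhibitor:
compound 1 `CC1CC(C)CN(c2nc(C(F)(F)Cl)ccc2CNC(=O)C(C)c2ccc(NS(C)(=O)=O)c(F)c2)C1` gives 1 nM
compound 2 `CC(C(=O)NCc1ccc(C(F)(F)Cl)nc1N1CCN(c2ccccc2)CC1)c1ccc(NS(C)(=O)=O)c(F)c1` gives 0.8 nM
compound 3 `CC(C)COc1nc(C(F)(F)Cl)ccc1CNC(=O)C(C)c1ccc(NS(C)(=O)=O)c(F)c1` gives 0.6 nM

Compound 3 has the lowest of the three numbers, but its steps to both neighbours stay within the scatter: a 1.7-fold lower number from compound 1 to compound 3 (0.22 log units; within the scatter) and a 1.3-fold lower number from compound 2 to compound 3 (0.12 log units; within the scatter), as does the step between the other two, a 1.3-fold lower number from compound 1 to compound 2 (0.10 log units; within the scatter). No order among the three can be read from this.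

Compound 4 `CC(C(=O)NCc1ccc(C(F)(F)Cl)nc1OCc1cccnc1)c1ccc(NS(C)(=O)=O)c(F)c1` keeps the shared core and the isobutoxy-type ether of compound 3 and changes the chain end: pyridin-3-yl in place of isopropyl on a saturated chain carbon bound to an oxygen on an aromatic ring.

Among the measured compounds shown here, none of the measured steps touches this chain carbon; all three concern the substituent directly on the aromatic carbon, where exchanging a saturated ring amine, an arylpiperazine and an ether left the numbers within the scatter of one another. For the measured compounds named here, that tolerance at the neighbouring attachment is the only guide for compound 4, so a step in this assay of no more than the scatter is expected in either direction.

For compound 4 an estimate of 0.8 nM is taken, with a range of 0.3 nM to 2.5 nM, corresponding to an expected step of a 1.3-fold higher number from compound 3 to compound 4 (0.12 log units; within the scatter).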

Compound 4, inhibition constant: 14.6 nM
Compound 4: middle estimate off by 18-fold (1.26 log units), on the low side, and the stated range ends below it.
By their numbers in this assay, from the lowest: compounds 3, 2 and 1 (each within the scatter of the next); then compound 4.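

In this assay, among the compounds shown here, the end of the ether chain proves sensitive: pyridin-3-yl in place of isopropyl on a saturated chain carbon bound to an oxygen on an aromatic ring gives a 24-fold higher number from compound 3 to compound 4 (1.39 log units; beyond the scatter), whereas every step among the earlier compounds stayed within the scatter. The apparent tolerance on the aromatic carbon therefore covers isobutoxy, 4-phenylpiperazin-1-yl and 3,5-dimethylpiperidin-1-yl but does not extend to (pyridin-3-yl)methoxy, which stands apart from the two amine substituents with an 18-fold higher number from compound 2 to compound 4 (1.26 log units; beyond the scatter) and a 15-fold higher number from compound 1 to compound 4 (1.16 log units; beyond the scatter), so compound 4 is the one exception to that tolerance. No measurement at hand accounts for the size of these steps, and the finding rests on compound 4 alone.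

Still open, from the compounds shown here alone, is whether the step belongs to the ring nitrogen or to the ring itself: a phenyl or a cyclohexyl on the same chain carbon would separate the two. Also open, going by these compounds, is how a longer chain carrying the pyridin-3-yl, or a hydroxyl or dimethylamino group at the chain end, would read in this assay.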